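Swapping a Ring Amine for an Open Chain Amine

The source may hold more compounds than are shown below. What is called first, only, known or untested is meant among the compounds shown, and "the series" means these compounds.

Compound 1 `O=C1c2c[n+]([O-])c3ccccc3c2C(=O)c2c1c1ccccc1n2CCCCN1CCCCC1` is tested in a functional assay on MDA-MB-231 cells (Homo sapiens) for cytotoxicity, read by MTT assay, with a stated time of 72 h (a higher number here means a weaker inhibitor, a lower number a stronger inhibitor), and gives 610 nM. Going by the values given here, this is the higher of the two values measured so far, though compound 2 `CC1(C)OC[C@H](Cn2cc(Cn3c4c(c5ccccc53)C(=O)c3c[n+]([O-])c5ccccc5c3C4=O)nn2)O1`, which gives 530 nM, lies within the scatter of it. Compound 3 `CN(C)CCCCCn1c2c(c3ccccc31)C(=O)c1c[n+]([O-])c3ccccc3c1C2=O` has not yet been measured. It differs from compound 1 by (dimethylamino)methyl in place of piperidin-1-yl on a saturated chain carbon, four bonds along the chain from an aromatic nitrogen. Among the compounds with values here, no measured pair shows this change, so the expected step of a 1.0-fold lower number from compound 1 to compound 3 (0.01 log units; within the scatter) is modest and probably within the scatter. Compound 3 is therefore estimated at 600 nM, with a range from 250 nM to 1500 nM.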

Compound 3, half-maximal inhibitory concentration: 240 nM
Compound 3: middle estimate off by 2.5-fold (0.40 log units), on the high side, and the stated range ends above it.
By their numbers in this assay, from the lowest: compound 3; then compounds 2 and 1 (each within the scatter of the next).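

In this assay, the amine at the end of this chain is not interchangeable: the step is a 2.5-fold lower number from compound 1 to compound 3 (0.41 log units; beyond the scatter) and marks the first clear gap among these compounds. Opening the piperidine ring therefore goes with a stronger result here, in this single pair. Nothing available explains why.

Read one bond further out, the change is also 3-(piperidin-1-yl)propyl to 4-(dimethylamino)butyl, so the open amine and the longer chain cannot be separated. From the compounds shown here alone, how a diethylamino group or a morpholine ring would behave on this chain remains open.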